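This account rests on a few compounds, and the source may have more. Where it says the series, first, only, none or still open, it means among the compounds named here.

Measured so far in an assay on CHO-K1 cells for displacement of a labelled ligand from prostaglandin E2 receptor EP1 subtype (Homo sapiens); on this read-out lower numbers stand for stronger inhibition and higher numbers for weaker inhibition:
compound 1 `CNC(=O)c1cc(C)n(Cc2cc(Cl)ccc2OCc2ccccc2)n1`: 100 nM
compound 2 `Cc1cc(C(=O)Nc2ccc(F)cc2)nn1Cc1cc(Cl)ccc1OCc1ccccc1`: 79.4 nM
compound 3 `Cc1cc(C(=O)Nc2ccccn2)nn1Cc1cc(Cl)ccc1OCc1ccccc1`: 126 nM

Compound 3 holds the highest of the three numbers in this assay, but the steps of a 1.3-fold higher number from compound 1 to compound 3 (0.10 log units; within the scatter) and a 1.6-fold higher number from compound 2 to compound 3 (0.20 log units; within the scatter) both sit within the scatter, so the three compounds cannot be told apart on these data. Compound 4 `Cc1cc(C(=O)NCc2ccncc2)nn1Cc1cc(Cl)ccc1OCc1ccccc1` differs from compound 3 in one place: (pyridin-4-yl)methyl in place of pyridin-2-yl on an amide-type nitrogen. Every measured step here also swaps the group on the amide-type nitrogen: a 1.3-fold lower number from compound 1 to compound 2 (0.10 log units; within the scatter), a 1.3-fold higher number from compound 1 to compound 3 (0.10 log units; within the scatter) and a 1.6-fold higher number from compound 2 to compound 3 (0.20 log units; within the scatter), none beyond the scatter. On that basis the step of a 1.1-fold lower number from compound 3 to compound 4 (0.02 log units; within the scatter) is expected to stay within the scatter. Compound 4 is estimated at 120 nM in this assay, most likely between 50 nM and 300 nM.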

Compound 4, half-maximal inhibitory concentration: 79.4 nM
Compound 4: the middle estimate sits 1.5-fold (0.18 log units) above what was measured, and the stated range covers the measured number.
By their numbers in this assay, from the lowest: compounds 2, 4, 1 and 3 (each within the scatter of the next).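

In this assay, (pyridin-4-yl)methyl on the amide-type nitrogen gives only steps within the scatter: a 1.6-fold lower number from compound 3 to compound 4 (0.20 log units; within the scatter), no change at the digits printed from compound 2 to compound 4 (within the scatter) and a 1.3-fold lower number from compound 1 to compound 4 (0.10 log units; within the scatter). This position has now carried a group with a saturated chain carbon bound to that nitrogen, as well as methyl and directly attached aromatic rings, with no step beyond the scatter. No evidence is available to explain why these groups read alike.

Still open, as far as these compounds go, is whether a group of another kind on this nitrogen, such as a carboxylic acid or an amine on a longer chain, would give a step beyond the scatter. The compounds shown also leave open how changes elsewhere on the shared core would read.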